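The compounds below may be only part of what the source reports. "The series", "measured", "known", "first", "only" and "open" are said of these compounds alone.

Compound 1 `O=C(COc1ccc2cc(/C=C3/SC(=O)NC3=O)ccc2c1)Nc1ccc(Br)cc1F`: in an assay on isolated protein for inhibition of histone deacetylase 8 (Homo sapiens), with a stated time of 1 h (on this read-out lower numbers stand for stronger inhibition and higher numbers for weaker inhibition), compound 1 gives > 50000 nM, a limit of the assay.
Compound 2 `COc1cccc(NC(=O)COc2ccc3cc(/C=C4/SC(=O)NC4=O)ccc3c2)c1`: in this assay compound 2 gives 7600 nM.
Compound 3 `O=C(COc1ccc2cc(/C=C3/SC(=O)NC3=O)ccc2c1)Nc1cccc(C(F)(F)F)c1`: in this assay compound 3 gives > 50000 nM, a limit of the assay.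

Compound 3 therefore sits at the limit, where compound 1 also sits (the limit of > 50000 nM in this assay, at which 2 of the 3 values shown sit), and only compound 2 returns a number. Compound 4 `O=C(COc1ccc2cc(/C=C3/SC(=O)NC3=O)ccc2c1)Nc1ccc(F)cc1` carries 4-fluorophenyl in place of 3-(trifluoromethyl)phenyl on an amide-type nitrogen. Going by the values given here, two measured steps touch this position: an at least 6.5-fold higher number from compound 2 to compound 3 (0.81 log units; beyond the scatter), and a step that the two limits leave unreadable from compound 1 to compound 3. A halogenated phenyl ring on the amide nitrogen in compound 1 gave a limit, so compound 4 is expected to do much the same, with an at least 1.2-fold lower number from compound 3 to compound 4 (0.09 log units; that floor lies within the scatter) not readable as a step beyond the scatter. Compound 4 is estimated at 40000 nM, between 8000 nM and 100000 nM, most likely reported only as a limit.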

Compound 4, half-maximal inhibitory concentration: 6600 nM
Beside the measured number, compound 4's estimate is 6.1-fold (0.78 log units) above it, and the stated range ends above it.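

In this assay, a halogen on the phenyl ring on the amide-type nitrogen does not by itself bring the limit: 4-fluorophenyl gives an at least 7.5-fold lower number from compound 3 to compound 4 (0.87 log units; beyond the scatter), and an at least 7.5-fold lower number from compound 1 to compound 4 (0.87 log units; beyond the scatter). The 4-fluorophenyl ring also stands level with the 3-methoxyphenyl ring, with a 1.2-fold lower number from compound 2 to compound 4 (0.06 log units; within the scatter). Compound 1 and compound 3 stay at a limit of the assay: the limit of > 50000 nM in this assay, at which 2 of the 4 values shown sit.

Open, going by these compounds, is which part of the 4-bromo-2-fluorophenyl ring of compound 1 goes with its limit. Also open, on these data alone, is whether an amine, a carboxylic acid or a longer chain at this position would give a lower number.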